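The compounds below may be only part of what the source reports. "The series", "measured", "known", "first", "only" and "open" are said of these compounds alone.

Of the three numbers in an ADME assay on microsomes from liver (Mus musculus) for metabolic stability, with a stated time of 30 min, tested at 1 uM (on this read-out lower numbers stand for a less stable compound and higher numbers for a more stable compound), that of compound 2 `COc1cccc(S(=O)(=O)c2ccc(CN/C(=N\C#N)Nc3ccncc3)cc2)c1` is the highest: compound 2 gives 58%. Its gap to compound 3 `N#C/N=C(\NCc1ccc(S(=O)(=O)c2ccccc2)cc1)Nc1ccncc1`, which gives 57%, lies within the scatter, while its gap to compound 1 `N#C/N=C(\NCc1ccc(S(=O)(=O)c2ccccc2)cc1)Nc1cccnc1`, which gives 14%, lies beyond it. The step of a number 1 percentage points lower from compound 2 to compound 3 (within the scatter) removes a methoxy from an aromatic carbon, whereas a number 43 percentage points higher from compound 1 to compound 3 (beyond the scatter) puts pyridin-4-yl in place of pyridin-3-yl on an amine nitrogen. Compound 4 `N#C/N=C(\NCc1ccc(S(=O)(=O)N2CC3CCC(C2)O3)cc1)Nc1ccncc1` differs from compound 2 by a group of 8 heavy atoms (6 carbon, 1 nitrogen, 1 oxygen; one five-membered non-aromatic ring with 1 hetero atom, one six-membered non-aromatic ring with 2 hetero atoms) in place of a group of 8 heavy atoms (7 carbon, 1 oxygen; one six-membered aromatic ring of carbon only), on a sulfonyl sulfur. For the measured compounds named here, no measured step exchanges the group on the sulfonyl sulfur, so neither step bears closely on this change; no step beyond the scatter is expected in this assay, though with wide uncertainty. Compound 4 is estimated at 50%, between 25% and 75%, an expected step of a number 8 percentage points lower from compound 2 to compound 4 (within the scatter).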

Compound 4, percent of the compound remaining: 12%
For compound 4 the middle estimate is 38 percentage points above the measured one; the measured number lies below the stated range.
By their numbers in this assay, from the lowest: compounds 4 and 1 (each within the scatter of the next); then compounds 3 and 2 (each within the scatter of the next).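

The group on the sulfonyl sulfur proves to be a far more sensitive place in this assay than the methoxy on the aromatic ring had suggested: the exchange gives a number 46 percentage points lower from compound 2 to compound 4 (beyond the scatter) and likewise a number 45 percentage points lower from compound 3 to compound 4 (beyond the scatter) when the comparison is made without the methoxy. Both aromatic compounds therefore stand apart from the non-aromatic two-ring group, whether or not the methoxy is present. No measurement here accounts for this drop. From the compounds shown here alone, whether a simple morpholine or piperidine on the sulfonyl sulfur would stay close to compound 3 or fall as far as compound 4 remains open.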